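The compounds below may be only part of what the source reports. "The series", "measured", "known", "first", "only" and "open" are said of these compounds alone.

In a physicochemical assay for solubility, read by HPLC, measured as thermodynamic solubility, with a stated time of 4 h, at pH 6.8 (on this read-out lower numbers stand for lower solubility and higher numbers for higher solubility), compound 1 (`Cc1ccc(Oc2ccc3nc(COc4cccc(C(=O)O)c4)n(C)c3n2)cc1`) gives 33 ug/mL and compound 2 (`Cn1c(COc2cccc(C(=O)O)c2)nc2ccc(Oc3ccc4c(c3)OCC4)nc21`) gives 17 ug/mL as the two reference points. Compound 3 (`Cn1c(COc2cccc(C(=O)O)c2)nc2ccc(Oc3cc(Cl)ccn3)cc21`) gives 11 ug/mL as its number, which lies within the scatter of compound 2 and beyond the scatter of compound 1, whose number is the higher.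

Going by the values given here, compound 4 (`Cc1ccc(Oc2ccc3nc(COc4cccc(C(=O)O)c4)n(C)c3c2)nc1C`) has no measurement yet. It departs from compound 3 by 5,6-dimethylpyridin-2-yl in place of 4-chloropyridin-2-yl on an oxygen on an aromatic ring and so carries 5,6-dimethylpyridin-2-yl in place of 4-chloropyridin-2-yl on an oxygen on an aromatic ring.

Among the compounds with values here, only one measured step bears on this change. It is a 1.9-fold lower number from compound 1 to compound 2 (0.29 log units; within the scatter) and it also exchanges the group at that place, though on the core of compound 1 rather than that of compound 3. Within the data shown here, no measured step removes 4-chloropyridin-2-yl or brings in 5,6-dimethylpyridin-2-yl, so the guidance is thin. With that single step as the guide, no step beyond the scatter is expected in this assay for this change, and no direction is firmly indicated.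

The expected change is a 1.3-fold higher number from compound 3 to compound 4 (0.10 log units; within the scatter) and remains an estimate. For compound 4 the estimated value is 14 ug/mL with an expected range from 5 ug/mL to 35 ug/mL.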

Compound 4, solubility: 190 ug/mL
Compound 4: middle estimate off by 14-fold (1.13 log units), on the low side; measured number above the stated range.
By their numbers in this assay, from the lowest: compounds 3, 2 and 1 (each within the scatter of the next, the first and the last beyond it); then compound 4.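

In this assay, 5,6-dimethylpyridin-2-yl in place of 4-chloropyridin-2-yl on an oxygen on an aromatic ring gives a 17-fold higher number from compound 3 to compound 4 (1.24 log units; beyond the scatter), so on the core of compound 3 an exchange at this place can produce a large step, and that step is beyond the scatter. Going by these compounds alone, the only earlier step at this place, a 1.9-fold lower number from compound 1 to compound 2 (0.29 log units; within the scatter), lay within the scatter, on the core of compound 1 and with different groups, so it gave no sign of a move of this size; the new step also arises with one six-membered aromatic ring with 1 hetero atom on both sides and with the same counts of hydrogen-bond donors and acceptors and no net charge. Nothing available explains the size of this step.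

This single pair does not separate the loss of the chlorine from the arrival of the two methyl groups, and an unsubstituted pyridin-2-yl or a pyridin-2-yl bearing one methyl would bear on that split. Also open, on these data alone, is whether the same exchange gives a step of similar size on the core of compound 1, and how an amine on this pyridine ring would read.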